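The compounds below may be only part of what the source reports. "The series", "measured", "known", "first", "only" and "open" are said of these compounds alone.

Measured compounds:
- compound 1 `ClCc1ccc(Cn2cnc3c(Cl)ncnc32)cc1`: 2230 nM
- compound 2 `ClCc1cccc(Cn2cnc3c(Cl)ncnc32)c1`: 3090 nM

In a functional assay on COLO 205 cells (Homo sapiens) for cytotoxicity, read by sulforhodamine B assay, with a stated time of 48 h (on this read-out higher numbers stand for weaker inhibition of growth and lower numbers for stronger inhibition of growth), compound 1 gives 2230 nM, the smaller of the two numbers, while compound 2 gives 3090 nM; the gap between them falls within the scatter, so the two are not separated. Going by the values given here, no pair of measured compounds differing in a single place exists, so no measured step is available to guide the next change.

Compound 3 `ClCc1ccc(Cn2cnc3c(Cl)nc(Cl)nc32)cc1` differs from compound 1 by chloro in place of hydrogen on an aromatic carbon. Among the compounds with values here, the change adds a second chloro group to the shared core; nothing among the measured compounds shows what such an addition does in this assay. The step of a 1.2-fold lower number from compound 1 to compound 3 (0.09 log units; within the scatter) is expected to be small, in either direction, and possibly not beyond the scatter. Compound 3 is therefore expected at about 1800 nM, with a range from 500 nM to 6000 nM.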

Compound 3, concentration for 50% growth inhibition: 3470 nM
Estimate against measurement, compound 3: 1.9-fold (0.29 log units) below; low and high end bracket the measured number.
By their numbers in this assay, from the lowest: compounds 1, 2 and 3 (each within the scatter of the next).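

In this assay, chloro in place of hydrogen on an aromatic carbon, between two ring nitrogen atoms, gives a 1.6-fold higher number from compound 1 to compound 3 (0.19 log units; within the scatter) and so does not separate the two compounds. Going by these compounds alone, this is the first single-place step, and it shows that this position of the shared core can carry a second chloro group with growth inhibition still within the scatter of compound 1. Nothing available explains this outcome.

On these data alone, whether an amine, a methoxy group or a longer chain at this same position would give a step beyond the scatter remains open. Also open, as far as these compounds go, is whether chloro in place of hydrogen here would give a similar step on the core of compound 2.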